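Adding a Methoxy Group to Compound 2

The source may report more compounds than this note shows. Statements on the series, on what has been measured and on what is new or still open speak of the compounds shown alone.

Compound 1 `COc1ccc(-c2nc3sc(-c4ccccc4)cn3n2)cc1`: 16%
Compound 2 `Clc1ccc(-c2cn3nc(-c4ccccc4)nc3s2)cc1`: 14%

In a functional assay on DU-145 cells (Homo sapiens) for inhibition, read by sulforhodamine B assay, with a stated time of 48 h, tested at 10 uM (a higher number here means more inhibition of growth at the concentration tested, a lower number less inhibition of growth), compound 2 gives 14%, within the usual scatter of compound 1, so the two cannot be told apart. Compound 3 `COc1ccc(-c2nc3sc(-c4ccc(Cl)cc4)cn3n2)cc1` differs from compound 2 by one change: methoxy in place of hydrogen on an aromatic carbon. A methoxy stands in place of hydrogen on an aromatic carbon, para to a large group. Within the data shown here, no measured pair shows this change alone, but compound 1, which also carries a methoxy, gives 16%. No step beyond the scatter is expected, and the estimated step is a number 3 percentage points higher from compound 2 to compound 3 (within the scatter). Compound 3 is estimated at 17%, with an expected range of 6% to 32%.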

Compound 3, percent growth inhibition at one concentration: 19.3%
Estimate against measurement, compound 3: 2.3 percentage points below, within the range that was stated.
By their numbers in this assay, from the lowest: compounds 2, 1 and 3 (each within the scatter of the next).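

Methoxy in place of hydrogen on an aromatic carbon, para to a large group, now has its own measured pair in this assay, with a number 5.3 percentage points higher from compound 2 to compound 3 (within the scatter). Chloro in place of hydrogen on an aromatic carbon can also be read directly, with a number 3.3 percentage points higher from compound 1 to compound 3 (within the scatter), so neither change separates its pair at this concentration. No measurement at hand bears on why these steps are so small.

Still open, from the compounds shown here alone, is whether a different group at this place, such as an amine or a carboxylic acid, would give a step beyond the scatter.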